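This account rests on a few compounds, and the source may have more. Where it says the series, first, only, none or still open, it means among the compounds named here.

Of the compounds shown here, two have so far been tested in a functional assay on RPMI-8226 cells (Homo sapiens) for cytotoxicity, read by sulforhodamine B assay, with a stated time of 48 h, tested at 100 uM; on this read-out higher numbers stand for a weaker effect at the one concentration tested and lower numbers for a stronger effect. Compound 1 `COc1cc(-c2cc(/C=C/C(=O)c3ccc(N)cc3)[nH]n2)cc(OC)c1OC` gives -40%, the higher of the two numbers. Compound 2 `COc1ccc(-c2cc(/C=C/C(=O)c3ccc(OC)c(OC)c3)[nH]n2)cc1` gives -62%, a number that lies beyond the scatter from that of compound 1. Compound 3 `COc1cc(-c2cc(/C=C/C(=O)c3ccc(Cl)c(Cl)c3)[nH]n2)cc(OC)c1OC` has not yet been tested. Against compound 1 its change is 3,4-dichlorophenyl in place of 4-aminophenyl on a carbonyl carbon. Among the compounds with values here, no measured pair shows what such a change does, so the direction remains open. A modest move toward a stronger effect is nevertheless expected, a number 10 percentage points lower from compound 1 to compound 3 (within the scatter), and one within the scatter would not surprise. For compound 3 the expected value in this assay is -50%, between -85% and -15%.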

Compound 3, a percentage reported as activity, at one concentration (the size of the read-out at that concentration, not a potency): -25%
Beside the measured number, compound 3's estimate is 25 percentage points below it; low and high end bracket the measured number.
By their numbers in this assay, from the lowest: compound 2; then compound 1; then compound 3.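

In this assay the group on the carbonyl carbon proves able to shift the read-out: 3,4-dichlorophenyl in place of 4-aminophenyl gives a number 15 percentage points higher from compound 1 to compound 3 (beyond the scatter) and so a weaker effect. This single change shows that the shared core alone does not fix the result. No measurement at hand explains the shift. The compounds shown leave open whether removing the amino group or adding the two chlorines counts for more, and how a plain phenyl or a 4-hydroxyphenyl group would behave at this place.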